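The compounds below may be only part of what the source reports. "The series", "measured", "known", "first", "only" and "open" are said of these compounds alone.

Within the data shown here, compound 1 `C/C(=C\C(=O)Nc1ccccc1OCCCC(=O)O)c1ccc2c(ccn2C)c1` gives 780 nM in an assay on Prostate gland for inhibition of steroid 5-alpha-reductase (Rattus norvegicus) (a higher number here means a weaker inhibitor, a lower number a stronger inhibitor), the highest of the three numbers known so far. Compound 2 `CC(C)=CCn1ccc2cc(/C(C)=C/C(=O)Nc3ccccc3OCCCC(=O)O)ccc21` gives 120 nM in this assay, and compound 3 `CCCCc1ccc(Cn2ccc3cc(/C(C)=C/C(=O)Nc4ccccc4OCCCC(=O)O)ccc32)cc1` gives 100 nM in this assay. The step of a 6.5-fold lower number from compound 1 to compound 2 (0.81 log units; beyond the scatter) and the step of a 7.8-fold lower number from compound 1 to compound 3 (0.89 log units; beyond the scatter) both lie beyond the scatter, while the step of a 1.2-fold lower number from compound 2 to compound 3 (0.08 log units; within the scatter) lies within it. Compound 4 `C/C(=C\C(=O)Nc1ccccc1OCCCC(=O)O)c1ccc2c(ccn2Cc2ccc(C(C)(C)C)cc2)c1` has not yet been measured. It differs from compound 1 by 4-(tert-butyl)phenyl in place of hydrogen on a saturated chain carbon bound to an aromatic nitrogen. The two measured steps away from compound 1 bear directly on this change, since each of them also replaces hydrogen on the same saturated chain carbon bound to an aromatic nitrogen, and the 4-butylphenyl of compound 3 is the closest match to the 4-(tert-butyl)phenyl entering here. The step expected in this assay is therefore a 7.8-fold lower number from compound 1 to compound 4 (0.89 log units; beyond the scatter), of the modest size seen for the other two groups. Compound 4 is estimated at 100 nM in this assay, within a range from 45 nM to 250 nM.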

Compound 4, half-maximal inhibitory concentration: 170 nM
The estimate for compound 4 lay 1.7-fold (0.23 log units) below the measured number; low and high end bracket the measured number.
By their numbers in this assay, from the lowest: compounds 3, 2 and 4 (each within the scatter of the next); then compound 1.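

In this assay, 4-(tert-butyl)phenyl on the saturated chain carbon bound to an aromatic nitrogen also gives a lower number (a 4.6-fold lower number from compound 1 to compound 4 (0.66 log units; beyond the scatter)), so the gain over compound 1 now holds for three different groups at this position. Neither tert-butyl in place of butyl on an aromatic carbon (a 1.7-fold higher number from compound 3 to compound 4 (0.23 log units; within the scatter)) nor 4-(tert-butyl)phenyl in place of 2-methylprop-1-en-1-yl (a 1.4-fold higher number from compound 2 to compound 4 (0.15 log units; within the scatter)) gives a difference beyond the scatter, so these three groups cannot be told apart in this assay. No measurement at hand speaks to the cause of these numbers.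

The compounds shown leave open whether plain phenyl, without any alkyl group, would give a number in the same range. They also leave open how a chain ending in an amine or a carboxylic acid would fare at this position.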